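The source may report more compounds than this note shows. Statements on the series, on what has been measured and on what is new or still open speak of the compounds shown alone.

Compound 1: `O=C(Nc1ccccc1OC(F)(F)F)Nc1n[nH]c2ccccc12` — 31400 nM
Compound 2: `Nc1nn(C(=O)Nc2ccc(Cc3ccccc3)cc2)c2ccccc12` — 13500 nM
Compound 3: `COc1ccc(NC(=O)Nc2n[nH]c3ccccc23)cc1` — a limit, > 100000 nM

Of the compounds shown here, three have been tested in a functional assay on PC-3 cells (Homo sapiens) for inhibition, read by sulforhodamine B assay, with a stated time of 48 h; on this read-out lower numbers stand for stronger inhibition of growth and higher numbers for weaker inhibition of growth. Compound 2 gives the lowest of the two numbers shown; compound 1 gives a higher number, and the gap between them lies beyond the usual scatter. Compound 3 does not give a number at all: it reaches only (the limit of > 100000 nM in this assay, at which 1 of the 3 values shown sits).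

Compound 4, `CCCCOc1ccc(NC(=O)n2nc(N)c3ccccc32)cc1`, has not yet been measured in this assay. It differs from compound 2 in one place: butoxy in place of benzyl on an aromatic carbon. Going by the values given here, no step between measured compounds covers this kind of exchange, so no measured size can be drawn on. Among the compounds with values here, the only other compound carrying an alkoxy group, compound 3, sits at the limit, but it differs from compound 2 in more than one place, so its value shows only that an alkoxy-bearing analogue can fall outside the measured range. On that basis compound 4 is expected to give a weaker result than compound 2, a step in this assay of a 2.6-fold higher number from compound 2 to compound 4 (0.41 log units; beyond the scatter). The estimate for compound 4 is 35000 nM, with a range from 10000 nM to 100000 nM.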

Compound 4, concentration for 50% growth inhibition: 14900 nM
Beside the measured number, compound 4's estimate is 2.3-fold (0.37 log units) above it; measured number inside the range.
By their numbers in this assay, from the lowest: compounds 2 and 4 (each within the scatter of the next); then compound 1. At a limit, above all of these: compound 3.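

In this assay, the exchange of benzyl for butoxy on an aromatic carbon, para to a large group, comes out as a 1.1-fold higher number from compound 2 to compound 4 (0.04 log units; within the scatter). Going by these compounds alone, this position therefore accepts a chain with no ring and a hydrogen-bond acceptor in place of benzyl and its six-membered aromatic ring with no step beyond the scatter, something the earlier compounds, which offered no step at all, could not show. Nothing shown bears on why the two groups give values within the scatter of each other.

On these data alone, whether an amine, a carboxylic acid or a longer chain such as hexyloxy at this position would also stay within the scatter of compound 2 remains open. Also open, as far as these compounds go, is whether the same exchange would give a step of like size on the core of compound 1.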